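Sulfanyl for chloro across two side-chain cores

A few compounds are considered here, and "the series" means these few. Any claim that something is new, unique, unknown or untested is made for them only; others in the source may bear on it.

Four compounds, three of them read in a functional assay on FM3A cells (Homo sapiens) for inhibition, with FM3A (Mus musculus) as the target; a lower number here means a stronger inhibitor, a higher number a weaker inhibitor. Compound 1 `CC(=O)OC(C)n1cnc2c(Cl)nc(N)nc21` carries a chloro group. In this assay compound 1 reaches only the assay limit, > 500000 nM. Compound 2 `CC(=O)OCCOn1cnc2c(Cl)nc(N)nc21` carries the same chloro group on a core with a different side chain; the difference between the two cores is not broken down here. In this assay compound 2 also reaches only the assay limit, > 500000 nM. Compound 3 `CC(=O)OC(C)n1cnc2c(S)nc(N)nc21` is compound 1 with the change (sulfanyl in place of chloro on an aromatic carbon). In this assay compound 3 gives 366000 nM. The measured step is an at least 1.3-fold lower number from compound 1 to compound 3 (0.13 log units; that floor lies within the scatter), known only as a floor because of the limit of > 500000 nM in this assay, at which 2 of the 3 values shown sit.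

Compound 4 `CC(=O)OCCOn1cnc2c(S)nc(N)nc21` is compound 2 with the change (sulfanyl in place of chloro on an aromatic carbon). The place of the change reads word for word the same as for compound 1 to compound 3, so this is the same change, made twice in the series.

The expected step is an at least 1.2-fold lower number from compound 2 to compound 4 (0.09 log units; that floor lies within the scatter), resting on the floor an at least 1.3-fold lower number from compound 1 to compound 3 (0.13 log units; that floor lies within the scatter) seen on the other core. Since the step on the first core is only a floor at the limit, the size on the second core remains uncertain, and a limit rather than a number is a real possibility. Compound 4 is expected in this assay near 400000 nM, within roughly 150000 nM to 1000000 nM.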

Compound 4, half-maximal inhibitory concentration: 2000 nM
Compound 4: the middle estimate sits 200-fold (2.30 log units) above what was measured; the measured number lies below the stated range.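

In this assay, sulfanyl in place of chloro on an aromatic carbon gives an at least 250-fold lower number from compound 2 to compound 4 (2.39 log units; beyond the scatter), so on the core of compound 2 the change is large and beyond the scatter. The same change on the core of compound 1 gives only an at least 1.3-fold lower number from compound 1 to compound 3 (0.13 log units; that floor lies within the scatter), so the series does not show that a step of this size carries from one core to the other, nor does it show that the two steps differ: the same change on two cores in this assay, an at least 1.3-fold lower number (0.13 log units; that floor lies within the scatter) from compound 1 to compound 3 and an at least 250-fold lower number (2.39 log units; beyond the scatter) from compound 2 to compound 4; the limit leaves it open whether they differ. Neither step has an exact size, as both chloro compounds are held at a limit and each step is known only as a floor: the limit of > 500000 nM in this assay, at which 2 of the 4 values shown sit.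

The two sulfanyl compounds can be read as plain numbers, with compound 3 at 366000 nM and compound 4 at 2000 nM, but the compounds shown do not settle how much of the large step depends on the side chain of compound 4 and whether it would hold on a longer chain. Also open, from the compounds shown here alone, is whether the sulfanyl group itself is needed at this aromatic carbon, or whether an amine or a hydroxyl group there would give a similar number on either core.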